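A few compounds are considered here, and "the series" means these few. Any claim that something is new, unique, unknown or untested is made for them only; others in the source may bear on it.

Working notes on the series. Going by the values given here, in a functional assay on U-251 cells (Homo sapiens) for inhibition, read by sulforhodamine B assay, with a stated time of 48 h, tested at 50 uM (on this read-out higher numbers stand for more inhibition of growth at the one concentration tested and lower numbers for less inhibition of growth), compound 1 `O=C(c1ccc(C(F)(F)F)c(F)c1)c1ccc2nc(NC(=O)C(F)(F)F)cn2c1` gives 38.4%, the lower of the two numbers so far. Among the compounds with values here, the only other measured compound, compound 2 `O=C(c1ccc2nc(NC(=O)C(F)(F)F)cn2c1)c1ccc(C(F)(F)F)cc1F`, gives 80.1%, a gap beyond the usual scatter.

The step under consideration leads to compound 3 `Cc1ccc(C(=O)c2ccc3nc(NC(=O)C(F)(F)F)cn3c2)cc1F`, not yet measured. It has methyl in place of trifluoromethyl on an aromatic carbon, ortho to a fluoro group and para to a large group (methyl in place of trifluoromethyl on an aromatic carbon). The rest of compound 1 stays unchanged.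

Within the data shown here, no measured step covers this exchange, so the data give no direct guide to its size in this assay. The spread between compound 1 at 38.4% and compound 2 at 80.1% shows that the numbers can lie far apart within this small set, so a wide range is kept. A small rise is expected, probably not beyond the scatter. The estimated change is a number 4.6 percentage points higher from compound 1 to compound 3 (within the scatter). For compound 3 the expected value is 43%, with an estimated range of 20% to 70%.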

Compound 3, percent growth inhibition at one concentration: 37.9%
For compound 3 the middle estimate is 5.1 percentage points above the measured one; measured number inside the range.
By their numbers in this assay, from the lowest: compounds 3 and 1 (each within the scatter of the next); then compound 2.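

In this assay, going by these compounds alone, the exchange of trifluoromethyl for methyl is the first step that can be read, and it comes to a number 0.5 percentage points lower from compound 1 to compound 3 (within the scatter) with the fluoro group and the rest of compound 1 left unchanged. At this place on the aromatic ring, ortho to a fluoro group and para to a large group, the read-out therefore does not separate the two groups, even though the exchange removes the three fluorine atoms and leaves a single carbon. No measurement at hand bears on why the two groups read alike here.

Still open, on these data alone, is whether in this assay other groups at this place, such as a chlorine atom, a methoxy group, an amine or a carboxylic acid, would give a step beyond the scatter. Also open, as far as these compounds go, is whether the same exchange of trifluoromethyl for methyl would give so small a step on the substitution pattern of compound 2, and whether the result extends to concentrations other than the one tested.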